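The source may hold more compounds than are shown below. What is called first, only, known or untested is meant among the compounds shown, and "the series" means these compounds.

Within the data shown here, compound 1 `Cc1ccccc1-n1cc(CN2C(=O)C[C@@H]3CC[C@@]2(C)C3(C)C)nn1` stands second highest of the three numbers so far in a functional assay on PANC-1 cells (Homo sapiens) for inhibition, read by MTT assay, with a stated time of 24 h (on this read-out lower numbers stand for stronger inhibition and higher numbers for weaker inhibition), where compound 1 gives 250 nM. Compound 2 `Cc1ccc(-n2cc(CN3C(=O)C[C@@H]4CC[C@@]3(C)C4(C)C)nn2)cc1` carries 4-methylphenyl in place of 2-methylphenyl on an aromatic nitrogen, and in this assay compound 2 gives 270 nM, so that a 1.1-fold higher number from compound 1 to compound 2 (0.03 log units; within the scatter). Compound 3 `CC1(C)[C@H]2CC[C@]1(C)N(Cc1cn(-c3cccc(Br)c3)nn1)C(=O)C2` carries 3-bromophenyl on that nitrogen; in this assay compound 3 gives 90 nM, with a 2.8-fold lower number from compound 1 to compound 3 (0.44 log units; beyond the scatter) and a 3.0-fold lower number from compound 2 to compound 3 (0.48 log units; beyond the scatter).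

Compound 4 `CC1(C)[C@H]2CC[C@]1(C)N(Cc1cn(-c3ccccc3Cl)nn1)C(=O)C2` differs from compound 1 by chloro in place of methyl on an aromatic carbon. Among the measured compounds shown here, no measured step exchanges methyl for chloro at the same place. The two steps that reach compound 3 swap a methyl group for a bromine but move it as well, and both lower the number beyond the scatter; the step from compound 1 to compound 2 shows that moving the methyl group alone changes nothing beyond the scatter. Compound 4 keeps its group where compound 1 has it, so the bromine steps bear on it only loosely. One would therefore expect for compound 4 a small lowering at most, a 1.6-fold lower number from compound 1 to compound 4 (0.19 log units; within the scatter), with an estimate of 160 nM and a range from 70 nM to 350 nM.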

Compound 4, half-maximal inhibitory concentration: 270 nM
Compound 4: middle estimate off by 1.7-fold (0.23 log units), on the low side; the range from low to high includes it.
By their numbers in this assay, from the lowest: compound 3; then compounds 1, 2 and 4 (each within the scatter of the next).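

In this assay, chloro in place of methyl on the aromatic carbon ortho to a large group leaves the number within the scatter (a 1.1-fold higher number from compound 1 to compound 4 (0.03 log units; within the scatter)), and the 2-chlorophenyl compound also reads alike with the 4-methylphenyl compound (no change at the digits printed from compound 2 to compound 4 (within the scatter)). A halogen on this ring therefore does not by itself go with a lower number: the step to the 2-chlorophenyl group from the 3-bromophenyl group goes beyond the scatter (a 3.0-fold higher number from compound 3 to compound 4 (0.48 log units; beyond the scatter)), so that among these four compounds only compound 3 stands apart, and compound 4 goes against any rule that covers halogens as a class. No measurement offered here accounts for this difference between compound 3 and compound 4.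

The compounds shown leave open whether the lower number of compound 3 belongs to bromine itself or to the place it holds on the ring, for no compound here separates the two. They also leave open how an amine, a carboxylic acid or a methoxy group would read in the place of the chloro of compound 4.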